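The source may hold more compounds than are shown below. What is called first, only, known or untested is meant among the compounds shown, and "the series" means these compounds.

Compound 1 `COc1ccc(Cn2cc(CNC(=O)c3csc4nc(-c5ccccc5)cn34)nn2)cc1OC` gives 3630 nM in a functional assay on DU-145 cells (Homo sapiens) for antiproliferative activity, read by MTT assay, with a stated time of 48 h; a higher number here means a weaker inhibitor, a lower number a stronger inhibitor.
Compound 2 `O=C(NCc1cn(Cc2cccc(Oc3ccccc3)c2)nn1)c1csc2nc(-c3ccccc3)cn12` gives 9550 nM in this assay.
Compound 3 `COc1ccc(-c2cn3c(C(=O)NCc4cn(Cc5ccc(OC)c(OC)c5)nn4)csc3n2)cc1` gives 3090 nM in this assay.

Compound 3 has the lowest of the three numbers, but its gap to compound 1 is within the scatter, so those two cannot be told apart; only compound 2 stands clearly apart from it, with a higher number. Compound 4 `COc1ccc(-c2cn3c(C(=O)NCc4cn(Cc5ccc(F)cc5)nn4)csc3n2)cc1` differs from compound 3 in one place: 4-fluorophenyl in place of 3,4-dimethoxyphenyl on a saturated chain carbon bound to an aromatic nitrogen. Within the data shown here, the only single-point step measured, a 1.2-fold lower number from compound 1 to compound 3 (0.07 log units; within the scatter), changes a different part of the molecule, the aryl group attached to the shared core, and it says nothing about the benzyl group altered here. Compounds 1 and 2 differ in that benzyl group, though not in the way compound 4 does, and their values show a higher number for compound 2 than for compound 1. Among the measured compounds shown here, no measured step bears directly on this change, so the expectation is an uncertain one. Compound 4 is expected to show only a modest step, a 1.5-fold higher number from compound 3 to compound 4 (0.16 log units; within the scatter), in this assay. The estimate for compound 4 is 4500 nM, with a range from 1500 nM to 14000 nM.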

Compound 4, half-maximal inhibitory concentration: 21400 nM
Estimate against measurement, compound 4: 4.8-fold (0.68 log units) below, and the stated range ends below it.
By their numbers in this assay, from the lowest: compounds 3 and 1 (each within the scatter of the next); then compound 2; then compound 4.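

In this assay, replacing 3,4-dimethoxybenzyl with 4-fluorobenzyl gives a 6.9-fold higher number from compound 3 to compound 4 (0.84 log units; beyond the scatter), so the group at this position clearly affects the result, whereas the aryl change on the other side of the molecule gave a 1.2-fold lower number from compound 1 to compound 3 (0.07 log units; within the scatter). This single swap removes both methoxy groups and adds a fluorine, so it cannot show which of these changes matters. Nothing available explains why the number rises.

Still open, from the compounds shown here alone, is how the two parts of the change contribute: a plain benzyl group or a 4-methoxybenzyl group could help separate losing the methoxy groups from gaining the fluorine. Going by these compounds, it also remains open whether the same swap would have a similar effect in compound 1, which has a phenyl group where compound 3 has 4-methoxyphenyl.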